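Moving the chlorine on the phenoxy tail

The source may report more compounds than this note shows. Statements on the series, on what has been measured and on what is new or still open speak of the compounds shown alone.

Among the measured compounds shown here, compound 1 `NC1=NC2(CCOCC2)N(OCCCOc2ccccc2Cl)C(N)=N1` is one of two compounds measured in an assay on isolated protein for inhibition of Dihydrofolate reductase (Homo sapiens), read by spectrophotometry, using NADPH, with stated times of 5 s and 6 min, tested at 50 uM; a lower number here means a weaker effect, a higher number a stronger effect of the compound at the concentration tested; in it compound 1 gives 88.2%. Its partner compound 2 `NC1=NC2(CCSCC2)N(OCCCOc2ccccc2Cl)C(N)=N1` gives 89.6%, a gap within the usual scatter, so the two cannot be set apart. Compound 3 `NC1=NC2(CCOCC2)N(OCCCOc2cccc(Cl)c2)C(N)=N1` has not yet been measured; it differs from compound 1 by 3-chlorophenyl in place of 2-chlorophenyl on an oxygen on a saturated carbon. For the measured compounds named here, with only two near-identical measured numbers, no step between measured compounds can guide the size of this change, so the expectation is a small step, a number 4.2 percentage points lower from compound 1 to compound 3 (within the scatter), not beyond the scatter. Compound 3 is estimated at 84%, between 65% and 95%.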

Compound 3, a percentage reported as inhibition, at one concentration (the size of the read-out at that concentration, not a potency): 85.8%
Beside the measured number, compound 3's estimate is 1.8 percentage points below it; the measured number falls inside the stated range.
By their numbers in this assay, from the lowest: compounds 3, 1 and 2 (each within the scatter of the next).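

Placing the chlorine elsewhere on the ring gives the first step read at this position: in this assay, 3-chlorophenyl in place of 2-chlorophenyl on an oxygen on a saturated carbon gives a number 2.4 percentage points lower from compound 1 to compound 3 (within the scatter) and so does not set the two compounds apart. Nothing measured here offers an explanation for this result. As far as these compounds go, whether 4-chlorophenyl, an unsubstituted phenyl or a longer chain at this place would keep the number at this level remains open. A reading at one concentration is not a potency, so compound 1 and compound 3 could still differ at lower concentrations.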